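Nitro to Methoxy on a Shared Core

The compounds below may be only part of what the source reports. "The series", "measured", "known", "first", "only" and "open" are said of these compounds alone.

Two compounds share a large core and differ only in small places. Compound 1 `COc1ccc(-n2nc(C(=O)Nc3ccc(Oc4ccnc5cc(OCCCN6CCCC6)c(OC)cc45)c(F)c3)c3ccccc3c2=O)cc1` and compound 2 `COc1cc2c(Oc3ccc(NC(=O)c4nn(-c5ccc([N+](=O)[O-])cc5)c(=O)c5ccccc45)cc3F)ccnc2cc1OCCCN1CCCCC1` were both tested in a functional assay on NCI-H460 cells (Homo sapiens) for cytotoxicity, read by MTT assay, with a stated time of 72 h; a lower number here means a stronger inhibitor, a higher number a weaker inhibitor. In this assay compound 1 gives 1650 nM, and compound 2 gives 1300 nM. The gap between these two numbers is smaller than the scatter of repeated measurements, so the two compounds cannot be told apart on the data shown, and neither can be called more potent than the other.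

Compound 3 `COc1ccc(-n2nc(C(=O)Nc3ccc(Oc4ccnc5cc(OCCCN6CCCCC6)c(OC)cc45)c(F)c3)c3ccccc3c2=O)cc1` has not yet been measured. It is made from compound 2 by one change: methoxy in place of nitro on an aromatic carbon. Going by the values given here, no pair of measured compounds shows exactly this exchange, so no measured step can be quoted for it. Compound 3 also carries the same methoxy group that compound 1 carries, while it shares its chain with compound 2, and both of those compounds sit close together in this assay. The expected step from compound 2 to compound 3 is therefore a 1.2-fold higher number from compound 2 to compound 3 (0.06 log units; within the scatter), a change no larger than the scatter. In this assay compound 3 is estimated at 1500 nM, with a likely range from 700 nM to 3200 nM.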

Compound 3, half-maximal inhibitory concentration: 840 nM
Estimate against measurement, compound 3: 1.8-fold (0.25 log units) above, and the stated range covers the measured number.
By their numbers in this assay, from the lowest: compounds 3, 2 and 1 (each within the scatter of the next).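

Compound 1 and compound 2 differ in two places at once, so their numbers could not say what either place does alone, and compound 3 now separates the two places. In this assay the 4-nitrophenyl to 4-methoxyphenyl exchange, on an aromatic carbon para to a large group, gives a 1.5-fold lower number from compound 2 to compound 3 (0.19 log units; within the scatter) and the exchange of pyrrolidin-1-yl for piperidin-1-yl at the end of the chain gives a 2.0-fold lower number from compound 1 to compound 3 (0.29 log units; within the scatter) so neither single change moves the number beyond the scatter of repeated measurements, and in this small set both places tolerate the exchange without a detectable effect. Nothing measured here offers an explanation for these two readings.

Going by these compounds, each exchange is read only once, on a single partner compound and in a single cell assay, so it remains open whether either result would hold on a different background. Also open, on these data alone, is whether an amine or a carboxylic acid at the para place, or a longer chain in front of the piperidin-1-yl ring, would stay within the scatter of compound 3 or move the number clearly.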